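A few compounds are considered here, and "the series" means these few. Any claim that something is new, unique, unknown or untested is made for them only; others in the source may bear on it.

Measured compounds:
compound 1 `CC(C)C(c1ncc[nH]1)c1ccc(-c2ccc3cccc(F)c3c2)[nH]c1=O` with 33 nM
compound 2 `CC(C)C(c1ccc(-c2ccc3cccc(F)c3c2)[nH]c1=O)N1CCCCC1=O` with 40 nM
compound 3 `CC(C)C(Nc1nccs1)c1ccc(-c2ccc3cccc(F)c3c2)[nH]c1=O` with 10 nM

These three share one core and differ only in the group on a saturated chain carbon bound to an aromatic carbon and a saturated chain carbon. In a functional assay on CHO cells for antagonist activity at prostaglandin E2 receptor EP3 subtype (Homo sapiens), read by cAMP accumulation (on this read-out lower numbers stand for stronger inhibition and higher numbers for weaker inhibition), compound 3 gives the lowest number of the three; the step of a 3.3-fold lower number from compound 1 to compound 3 (0.52 log units; beyond the scatter) and the step of a 4.0-fold lower number from compound 2 to compound 3 (0.60 log units; beyond the scatter) are both beyond the scatter, while a 1.2-fold higher number from compound 1 to compound 2 (0.08 log units; within the scatter) is within it.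

Compound 4 `CC(C)C(c1ccc(-c2ccc3cccc(F)c3c2)[nH]c1=O)N1CCCCS1(=O)=O` is not yet measured. The change from compound 3 is a group of 8 heavy atoms (4 carbon, 1 nitrogen, 2 oxygen, 1 sulfur; one six-membered non-aromatic ring with 2 hetero atoms) in place of a group of 6 heavy atoms (3 carbon, 2 nitrogen, 1 sulfur; one five-membered aromatic ring with 2 hetero atoms), on a saturated chain carbon bound to an aromatic carbon and a saturated chain carbon. Among the measured steps, a 4.0-fold lower number from compound 2 to compound 3 (0.60 log units; beyond the scatter) bears most directly on it, since compound 2 also carries a six-membered non-aromatic ring with no hydrogen-bond donor at that place; a 3.3-fold lower number from compound 1 to compound 3 (0.52 log units; beyond the scatter) points the same way. Undoing the thiazolylamino is therefore expected to move the number back toward compound 2, a step of roughly a 4.0-fold higher number from compound 3 to compound 4 (0.60 log units; beyond the scatter). Compound 4 is estimated at 40 nM, with a range of 15 nM to 120 nM.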

Compound 4, half-maximal inhibitory concentration: 122 nM
For compound 4 the middle estimate is 3.1-fold (0.48 log units) below the measured one; measured number above the stated range.
By their numbers in this assay, from the lowest: compound 3; then compounds 1 and 2 (each within the scatter of the next); then compound 4.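

In this assay, the step of a 12-fold higher number from compound 3 to compound 4 (1.09 log units; beyond the scatter) is the largest seen so far at this place, a saturated chain carbon bound to an aromatic carbon and a saturated chain carbon. The step of a 3.1-fold higher number from compound 2 to compound 4 (0.48 log units; beyond the scatter) shows that two groups, each with a six-membered non-aromatic ring and no hydrogen-bond donor, need not give the same number, so those shared features do not alone set the value. With the step of a 3.7-fold higher number from compound 1 to compound 4 (0.57 log units; beyond the scatter) as well, compound 4 gives the highest number of the four, beyond the scatter from each of the others.

No data shown here explain these differences. On these data alone, it also remains open how a simple amine, a carboxylic acid or a phenylamino group would read at this place.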